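Chloro to Hydroxy: Cytotoxicity Expected to Remain at the Limit

The source may report more compounds than this note shows. Statements on the series, on what has been measured and on what is new or still open speak of the compounds shown alone.

Compound 3 `COc1nc(Cl)nc2c1ncn2[C@@H]1O[C@H](CO)[C@@H](O)[C@@]1(C)O` is one of three measured compounds built on a shared core. In an ADME assay on PBMC cells (Homo sapiens) for cytotoxicity, read by trypan blue exclusion, with a stated time of 6 days (on this read-out lower numbers stand for higher toxicity in this test and higher numbers for lower toxicity in this test), compound 3 gives > 100000 nM, which is a limit of the assay and not a number. Compound 1 `CC(C)(C)OC(=O)NOc1nc(N)nc2c1ncn2[C@@H]1O[C@H](CO)[C@@H](O)[C@@]1(C)O` in this assay gives > 100000 nM, also a limit. Compound 2 `C=C(OCC)c1nc(N)nc2c1ncn2[C@@H]1O[C@H](CO)[C@@H](O)[C@@]1(C)O` in this assay gives > 100000 nM, again a limit. Within the data shown here, the single measured step, a step that the two limits leave unreadable from compound 1 to compound 2, therefore stays unreadable. Where compound 3 stands is thus summarised by the limit of > 100000 nM in this assay, at which 3 of the 3 values shown sit: every value sits at the limit.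

Compound 4 `COc1nc(O)nc2c1ncn2[C@@H]1O[C@H](CO)[C@@H](O)[C@@]1(C)O` differs from compound 3 by hydroxy in place of chloro on an aromatic carbon. Among the measured compounds shown here, no measured step touches this change; the one available step, a step that the two limits leave unreadable from compound 1 to compound 2, concerns another part of the core and gives no readable size. With all three measured values at the limit, the step from compound 3 to compound 4 is expected to be a step that the limit leaves unreadable from compound 3 to compound 4, no change beyond the scatter in this assay. Compound 4 is therefore estimated at 150000 nM, within a range from 50000 nM to 400000 nM, and most likely reported only as a limit.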

Compound 4, half-maximal cytotoxic concentration: > 100000 nM
Compound 4: a limit, no number; the forecaster's own chance of this, stated with the estimate: 85%; the middle value lies beyond the limit too.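

Compound 3 and compound 4 both sit at a limit and not at a number, so no size can be read for hydroxy in place of chloro. The compounds shown leave open whether any change on the shared core would alter cytotoxicity: the limit of > 100000 nM in this assay, at which 4 of the 4 values shown sit.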